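Fluoro to chloro on the aryl of compound 1

This account rests on a few compounds, and the source may have more. Where it says the series, first, only, none or still open, it means among the compounds named here.

Among the measured compounds shown here, compound 1 `C#CCNC1CCc2c(SCc3cccc(F)c3)cccc21` is the strongest of the three measured members: in an assay on isolated protein for inhibition of Amine oxidase [flavin-containing] B (Homo sapiens) (a lower number here means a stronger inhibitor, a higher number a weaker inhibitor), compound 1 gives 1480 nM. Compound 2 `C#CCNC1CCc2c(SCCc3cccc(F)c3)cccc21`, which carries the two-carbon chain between sulfur and the aryl, gives in this assay 4300 nM; compound 3 `C#CCNC1CCc2c(SCCc3cccc(OC)c3)cccc21` gives in this assay 28700 nM. For the measured compounds named here, the one single-point step measured so far, a 6.7-fold higher number from compound 2 to compound 3 (0.82 log units; beyond the scatter), shows that replacing fluoro by methoxy on the aryl costs potency in this assay.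

Compound 4 `C#CCNC1CCc2c(SCc3cccc(Cl)c3)cccc21` differs from compound 1 by chloro in place of fluoro on an aromatic carbon. Going by the values given here, no measured pair swaps one halogen for another, so the step from compound 2 to compound 3 bears only indirectly: it shows the aryl substituent matters, but methoxy is not chloro. Chloro is expected to sit close to fluoro, with at most a small gain, so the step is estimated as a 1.5-fold lower number from compound 1 to compound 4 (0.17 log units; within the scatter). For compound 4 the estimate in this assay is 1000 nM, with a range from 350 nM to 3000 nM.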

Compound 4, half-maximal inhibitory concentration: 23300 nM
Compound 4: middle estimate off by 23-fold (1.37 log units), on the low side, outside the stated range (above it).
By their numbers in this assay, from the lowest: compound 1; then compound 2; then compounds 4 and 3 (each within the scatter of the next).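

In this assay, a single halogen exchange at this place, on an aromatic carbon meta to a large group, is a large step: a 16-fold higher number from compound 1 to compound 4 (1.20 log units; beyond the scatter). Fluoro and chloro are therefore not interchangeable in this series, although each counts as one heavy atom with no hydrogen-bond donors, no hydrogen-bond acceptors and no net charge, so those counts do not separate them. Nothing at hand gives a reason for the loss.

Going by these compounds, whether the loss belongs to chloro alone stays open: bromo, methyl, trifluoromethyl or an unsubstituted phenyl would show how the read-out follows the group at this place. Also open, on these data alone, is whether chloro on the two-carbon chain of compound 2 gives a step of similar size, or whether this one holds only for the chain of compound 1.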